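Swapping methyl for phenyl on a triazole acylguanidine

This account rests on a few compounds, and the source may have more. Where it says the series, first, only, none or still open, it means among the compounds named here.

Four compounds share a core in which an acylguanidine is linked through a three-carbon chain to a five-membered nitrogen ring. Compound 1 `CC(CC(=O)/N=C(\N)NCCCc1cn[nH]c1)c1ccccc1` is the reference point. In an assay on ileum for antagonist activity at histamine H1 receptor (Cavia porcellus), with a stated time of 15 min (a higher number here means weaker binding, a lower number tighter binding), compound 1 gives 3800 nM. Compound 2 `N/C(=N\C(=O)CC(c1ccccc1)c1ccccc1)NCCCc1cn[nH]c1` differs from it by phenyl in place of methyl on a saturated chain carbon bound to an aromatic carbon and a saturated chain carbon; in this assay compound 2 gives 2570 nM, and the step is a 1.5-fold lower number from compound 1 to compound 2 (0.17 log units; within the scatter). Compound 3 `CC(CC(=O)/N=C(\N)NCCCc1ncn[nH]1)c1ccccc1` differs from compound 1 at the ring, (1H-1,2,4-triazol-5-yl in place of 1H-pyrazol-4-yl on a saturated chain carbon, three bonds along the chain from an amine nitrogen); in this assay compound 3 gives 1480 nM, and the step is a 2.6-fold lower number from compound 1 to compound 3 (0.41 log units; beyond the scatter). The two values of compound 2 and compound 3 lie within the usual scatter of each other, so no order between them can be read.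

Compound 4 `N/C(=N\C(=O)CC(c1ccccc1)c1ccccc1)NCCCc1ncn[nH]1` has not been measured. It differs from compound 3 by phenyl in place of methyl on a saturated chain carbon bound to an aromatic carbon and a saturated chain carbon. This is the same change as that from compound 1 to compound 2, made at a place described in identical words, but on the core that carries the triazole. Going by the values given here, with only one earlier example of this change, the expectation rests on that single step, a 1.5-fold lower number from compound 1 to compound 2 (0.17 log units; within the scatter), which itself lay within the scatter. From compound 3, the expected step is a 1.5-fold lower number from compound 3 to compound 4 (0.17 log units; within the scatter). In this assay compound 4 is therefore expected to give about 1000 nM, with a likely range from 400 nM to 2500 nM.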

Compound 4, dissociation constant: 1620 nM
Estimate against measurement, compound 4: 1.6-fold (0.21 log units) below; low and high end bracket the measured number.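

In this assay, phenyl in place of methyl on the core that carries the triazole gives a 1.1-fold higher number from compound 3 to compound 4 (0.04 log units; within the scatter), a step too small to read as a real change, and it agrees with the same change on the core of compound 1: the same change on two cores in this assay, a 1.5-fold lower number (0.17 log units; within the scatter) from compound 1 to compound 2 and a 1.1-fold higher number (0.04 log units; within the scatter) from compound 3 to compound 4, 1.6-fold (0.21 log units) apart, within the scatter of two such steps. The ring exchange, 1H-1,2,4-triazol-5-yl in place of 1H-pyrazol-4-yl, gives a 1.6-fold lower number from compound 2 to compound 4 (0.20 log units; within the scatter) when phenyl is present, and although only the earlier step with methyl lay beyond the scatter, the two steps cannot be told apart: the same change on two cores in this assay, a 2.6-fold lower number (0.41 log units; beyond the scatter) from compound 1 to compound 3 and a 1.6-fold lower number (0.20 log units; within the scatter) from compound 2 to compound 4, 1.6-fold (0.21 log units) apart, within the scatter of two such steps. So within these four compounds, each change behaves alike on both cores, but this rests on only two pairs in this assay, and because the phenyl steps are so small, it does not show that a larger effect would carry from one core to another.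

The compounds shown leave open whether a different group on the saturated chain carbon, such as an amine or a carboxylic acid, would give a step beyond the scatter. They also leave open whether these changes would behave alike on a core with a longer chain leading to the ring.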